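Swapping 5-cyanopentyl for pyridin-4-yl on compound 3

The source may hold more compounds than are shown below. What is called first, only, known or untested is meant among the compounds shown, and "the series" means these compounds.

Measured in a physicochemical assay for solubility, in phosphate buffer, with a stated time of 18 h; on this read-out lower numbers stand for lower solubility and higher numbers for higher solubility:
- Compound 1 `Cc1ncc2c(N)c(C#N)c(N)nc2n1` gives 783000 nM
- Compound 2 `N#Cc1c(N)nc2nc(C3CCC3)ncc2c1N` gives 217000 nM
- Compound 3 `CC(C)(C)c1nc(CCCCCC#N)c2c(N)c(C#N)c(N)nc2n1` gives 6000 nM

Compound 3 has the lowest number of the three. Compound 4 `CC(C)(C)c1nc(-c2ccncc2)c2c(N)c(C#N)c(N)nc2n1` has pyridin-4-yl in place of 5-cyanopentyl on an aromatic carbon, and the tert-butyl group stays: pyridin-4-yl in place of 5-cyanopentyl on an aromatic carbon. For the measured compounds named here, only one measured step offers any guide, a 3.6-fold lower number from compound 1 to compound 2 (0.56 log units; beyond the scatter). It involves other groups, so it hints at a size but gives no firm direction. A modest step in this assay is therefore expected, and upward is only a tentative guess. The expected step is a 2.5-fold higher number from compound 3 to compound 4 (0.40 log units; beyond the scatter). The estimate for compound 4 is 15000 nM, within a range of 3000 nM to 70000 nM.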

Compound 4, solubility: 44000 nM
Beside the measured number, compound 4's estimate is 2.9-fold (0.47 log units) below it; low and high end bracket the measured number.
By their numbers in this assay, from the lowest: compound 3; then compound 4; then compound 2; then compound 1.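

In this assay, putting pyridin-4-yl in place of 5-cyanopentyl gives a 7.3-fold higher number from compound 3 to compound 4 (0.87 log units; beyond the scatter) while the tert-butyl group stays. The group on this aromatic carbon alone therefore moves the number beyond the usual scatter, which the earlier step, made at a different place on the core, could not show. No measurement here explains the change.

On these data alone, it remains open whether the aromatic ring or the loss of the nitrile chain matters more. An amine or a shorter chain at this position might also behave differently, and the step might not hold without the tert-butyl group.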